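The compounds below may be only part of what the source reports. "The series", "measured", "known", "first", "only" and "open" are said of these compounds alone.

Compound 1, `O=C(/C=C/C1=Cc2ccccc2OC1)c1ccccc1F`: 64.4%
Compound 2, `O=C(/C=C/C1=Cc2ccccc2OC1)c1ccc(F)cc1`: 65.6%
Compound 3, `O=C(/C=C/C1=Cc2ccccc2OC1)c1cccc(Br)c1`: 51.7%

In a functional assay on the whole organism for inhibition, with Mus musculus as the target, with a stated time of 1 h, at a dose of 30 mg/kg by the intraperitoneal route (on this read-out higher numbers stand for more inhibition at the one dose given (going by the name of the read-out) and lower numbers for less inhibition), compound 2 gives 65.6%. Compound 1 sits within the scatter of that number (a number 1.2 percentage points higher from compound 1 to compound 2 (within the scatter)), while compound 3 lies beyond it (a number 13.9 percentage points lower from compound 2 to compound 3 (beyond the scatter)). All three share one core and differ only in the group on the aromatic ring attached to the carbonyl.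

Compound 4, `O=C(/C=C/C1=Cc2ccccc2OC1)c1ccc(C(F)(F)F)cc1`, is the next step from compound 2: trifluoromethyl in place of fluoro on an aromatic carbon. Going by the values given here, two measured steps bear on it, since both alter the same ring. Moving fluoro to another place changed little (a number 1.2 percentage points higher from compound 1 to compound 2 (within the scatter)), whereas bromo at yet another place gave a modest drop (a number 13.9 percentage points lower from compound 2 to compound 3 (beyond the scatter) and a number 12.7 percentage points lower from compound 1 to compound 3 (beyond the scatter)). Among the compounds with values here, no measured step exchanges fluoro for trifluoromethyl at the same place, so the guide is loose. A small change, within the scatter or slightly downward, is expected in this assay.

Compound 4 is therefore estimated to give 60%, with a range from 45% to 75%. The expected step is a number 5.6 percentage points lower from compound 2 to compound 4 (within the scatter).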

Compound 4, a percentage reported as inhibition, in the whole organism at one dose (the size of the read-out at that dose, not a potency): 75.5%
Beside the measured number, compound 4's estimate is 15.5 percentage points below it; the measured number lies above the stated range.
By their numbers in this assay, from the lowest: compound 3; then compounds 1, 2 and 4 (each within the scatter of the next, the first and the last beyond it).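

The step of a number 9.9 percentage points higher from compound 2 to compound 4 (within the scatter) shows that in this assay this aromatic carbon, para to a large group, accepts trifluoromethyl in place of fluoro without a change beyond the scatter. Going by these compounds alone, the entering group has four heavy atoms where fluoro has one, so this place holds more than a single halogen atom, which the earlier compounds could not show, as each carries only fluoro or bromo on that ring. Nothing available explains why the two groups read alike.

On these data alone, whether this same place also accepts an amine, a carboxylic acid or a longer chain remains open. So does whether trifluoromethyl would read the same at the other places on that ring, and how these compounds would compare at other doses.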